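Pyridin-2-yl in place of 4-methylphenyl: expected topoisomerase effect

The compounds below may be only part of what the source reports. "The series", "measured", "known", "first", "only" and "open" are said of these compounds alone.

Of the compounds shown here, three built on one shared core have been measured in an assay on isolated protein for inhibition of DNA topoisomerase 1 (Homo sapiens), tested at 100 uM; a higher number here means a stronger effect of the compound at the concentration tested, a lower number a weaker effect. Compound 1 `Cc1ccccc1-c1cc(-c2ccc(Cl)o2)cc(-c2ccsc2)n1` gives 6.7%, compound 2 `Cc1ccc(-c2cc(-c3ccc(Cl)o3)cc(-c3ccsc3)n2)o1` gives 9.1%, and compound 3 `Cc1ccc(-c2cc(-c3ccc(Cl)o3)cc(-c3ccsc3)n2)cc1` gives 2.6%. Compound 3 holds the smallest of the three numbers, but its gaps to the others, a number 4.1 percentage points lower from compound 1 to compound 3 (within the scatter) and a number 6.5 percentage points lower from compound 2 to compound 3 (within the scatter), both lie within the scatter, so the three values cannot be told apart.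

Compound 4 `Clc1ccc(-c2cc(-c3ccsc3)nc(-c3ccccn3)c2)o1` differs from compound 3 in one place: pyridin-2-yl in place of 4-methylphenyl on an aromatic carbon. The two measured steps that touch this same position, a number 4.1 percentage points lower from compound 1 to compound 3 (within the scatter) and a number 6.5 percentage points lower from compound 2 to compound 3 (within the scatter), show that swapping one aromatic group for another there left this assay unchanged beyond the scatter. Going by the values given here, nothing among the measured compounds speaks for a larger effect from pyridin-2-yl, so compound 4 is expected to behave like its neighbours, with a step of a number 3.4 percentage points higher from compound 3 to compound 4 (within the scatter). Compound 4 is therefore estimated at 6%, in a range from 0% to 18%.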

Compound 4, a percentage reported as inhibition, at one concentration (the size of the read-out at that concentration, not a potency): 0%
The estimate for compound 4 lay 6 percentage points above the measured number; the measured number falls inside the stated range.
By their numbers in this assay, from the lowest: compounds 4, 3, 1 and 2 (each within the scatter of the next).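

With pyridin-2-yl, the position now carries a six-membered aromatic ring with a ring nitrogen and a hydrogen-bond acceptor, yet this assay does not separate it from the other groups: a number 2.6 percentage points lower from compound 3 to compound 4 (within the scatter), a number 6.7 percentage points lower from compound 1 to compound 4 (within the scatter) and a number 9.1 percentage points lower from compound 2 to compound 4 (within the scatter). The four aromatic groups tried at this position, 2-methylphenyl, 5-methylfuran-2-yl, 4-methylphenyl and pyridin-2-yl, therefore cannot be told apart in this read-out, whether or not the ring holds a hetero atom. No measurement at hand offers an explanation for this result.

The compounds shown say nothing about how an aliphatic amine or a carboxylic acid at this position would read. As far as these compounds go, the 5-chlorofuran-2-yl and thiophen-3-yl groups are the same in all four compounds, so their part in the read-out remains open.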